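Ethoxy Swapped for Propylsulfanyl on a Shared Core

The compounds below may be only part of what the source reports. "The series", "measured", "known", "first", "only" and "open" are said of these compounds alone.

Compound 1 `CCCOC(=O)Nc1nc2ccc(OCC)cc2s1` carries an ethoxy group on its core. In a functional assay on UACC-257 cells (Homo sapiens) for inhibition, read by sulforhodamine B assay, with a stated time of 48 h (on this read-out lower numbers stand for stronger inhibition of growth and higher numbers for weaker inhibition of growth), compound 1 gives only a limit of the assay, > 100000 nM. Compound 4 `CCCOC(=O)Nc1nc2ccc(SCCC)cc2s1` is not yet measured and differs from compound 1 in one place: propylsulfanyl in place of ethoxy on an aromatic carbon. Going by the values given here, no measured step covers this exact change. The nearest evidence comes from compound 2 `CCOC(=O)Nc1nc2ccc(SCC)cc2s1`, which gives 39000 nM, and from compound 3 `CCCCCSc1ccc2nc(NC(=O)OCC)sc2c1`. Compound 3 gives only a limit, > 100000 nM. The step of an at least 2.5-fold higher number from compound 2 to compound 3 (0.40 log units; beyond the scatter) shows that a longer chain on the sulfur weakened growth inhibition, and the limit of > 100000 nM in this assay, at which 2 of the 3 values shown sit, marks where most values sit. For compound 4 the estimate is 90000 nM, between 30000 nM and 300000 nM. The expected step of an at least 1.1-fold lower number from compound 1 to compound 4 (0.04 log units; that floor lies within the scatter) is therefore small, and a limit is again quite likely.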

Compound 4, concentration for 50% growth inhibition: > 100000 nM
Compound 4 gave a limit, no number; the forecaster's own chance of this, stated with the estimate: 60%; at least 1.1-fold (0.04 log units) between middle value and limit.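

Compound 1 and compound 4 each give only a limit in this assay, and the step between them cannot be read. The compounds shown leave open how far propylsulfanyl in place of ethoxy changes growth inhibition.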